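The compounds below may be only part of what the source reports. "The series", "measured", "known", "first", "only" and "open" are said of these compounds alone.

Measured in a functional assay on NCI-H520 cells (Homo sapiens); a lower number here means a stronger inhibitor of growth, a higher number a weaker inhibitor of growth:
- compound 1 `O=S(=O)(/C=C/c1ccc(F)cc1)Cc1ccc(Nc2ncnc3ccccc23)cc1`: 13000 nM
- compound 2 `O=S(=O)(/C=C/c1ccc(Cl)cc1)Cc1ccc(Nc2ncnc3ccccc23)cc1`: 46000 nM
- compound 3 `O=S(=O)(/C=C/c1ccc(O)cc1)Cc1ccc(Nc2ncnc3ccccc23)cc1`: 100000 nM

Compound 2 holds the middle of these three numbers. The smaller gap around it is a 2.2-fold higher number from compound 2 to compound 3 (0.34 log units; beyond the scatter), and the larger gap is a 3.5-fold higher number from compound 1 to compound 2 (0.55 log units; beyond the scatter).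

The next compound to be tested is compound 4 `O=S(=O)(/C=C/c1ccc(Cl)cc1)Cc1ccc(Nc2ncnc3ccc(Br)cc23)cc1`. It keeps everything in compound 2 except for one change in the shared core, bromo in place of hydrogen on an aromatic carbon. This carbon belongs to a six-membered aromatic ring of carbon only, part of a fused or bridged system of two rings.

Going by the values given here, none of the measured compounds carries a change at this place. All three steps instead exchange fluoro, chloro or hydroxy at another part of the molecule, so they serve only as a rough guide to size. The largest of them is a 7.7-fold higher number from compound 1 to compound 3 (0.89 log units; beyond the scatter), and the smallest is a 2.2-fold higher number from compound 2 to compound 3 (0.34 log units; beyond the scatter). On that basis, a modest step at most is expected in this assay, and the data give no firm direction. It may well stay within the scatter.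

The expected change is a 1.2-fold lower number from compound 2 to compound 4 (0.06 log units; within the scatter). For compound 4 the estimated value is 40000 nM, with an expected range from 12000 nM to 120000 nM.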

Compound 4, concentration for 50% growth inhibition: 13000 nM
Beside the measured number, compound 4's estimate is 3.1-fold (0.49 log units) above it; measured number inside the range.
By their numbers in this assay, from the lowest: compounds 1 and 4 (each within the scatter of the next); then compound 2; then compound 3.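

In this assay, putting bromo on this carbon of the shared core gives a 3.5-fold lower number from compound 2 to compound 4 (0.55 log units; beyond the scatter) and moves the number towards stronger inhibition of growth. Going by these compounds alone, the earlier steps all exchanged a group at the other end of the molecule, so only this new step shows that this position, on a six-membered aromatic ring of carbon only within the fused system, also affects the result, and by a step as large as a 3.5-fold higher number from compound 1 to compound 2 (0.55 log units; beyond the scatter) on the far ring. No measurement here bears on the reason for this step.

As far as these compounds go, it remains open whether this effect is specific to bromo or would also appear with a different group on the same carbon, such as methyl, methoxy or an amine, and whether such groups would push the number in the same direction. From the compounds shown here alone, it is also open whether bromo at this place would produce a similar step when the chloro group of compound 2 is replaced by the fluoro of compound 1 or the hydroxy of compound 3.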